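Benzyl for cyclohexyl on the imidazole nitrogen of compound 1

A few compounds are considered here, and "the series" means these few. Any claim that something is new, unique, unknown or untested is made for them only; others in the source may bear on it.

Compound 1 `c1ccc2c(-c3cn4ccnc4c(-c4ccc5ncn(C6CCCCC6)c5c4)n3)cccc2c1` was tested in a functional assay on Hs-578T cells (Homo sapiens) for inhibition, read by sulforhodamine B assay, with a stated time of 48 h, tested at 10 uM; on this read-out lower numbers stand for less inhibition and higher numbers for more inhibition at the one concentration tested (going by the name of the read-out). In this assay compound 1 gives 3.62%, the lowest of the two numbers measured. Its nearest neighbour is compound 2 `Fc1ccc(-c2cn3ccnc3c(-c3ccc4ncn(C5CCCCC5)c4c3)n2)cc1`, which in this assay gives 17.6%. Going by the values given here, the only measured step is a number 14 percentage points higher from compound 1 to compound 2 (beyond the scatter); that change sits on an aromatic carbon, at a different place from the one now in question.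

Compound 3 `c1ccc(Cn2cnc3ccc(-c4nc(-c5cccc6ccccc56)cn5ccnc45)cc32)cc1` differs from compound 1 by benzyl in place of cyclohexyl on an aromatic nitrogen. Among the compounds with values here, no measured step bears on this change, since the step from compound 1 to compound 2 concerns another position, so there is nothing to point to a shift in either direction. The step of a number 2.4 percentage points higher from compound 1 to compound 3 (within the scatter) is therefore expected to stay within the scatter. Compound 3 is estimated at 6%, with a range from -6% to 22%.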

Compound 3, a percentage reported as inhibition, at one concentration (the size of the read-out at that concentration, not a potency): 5.98%
Estimate against measurement, compound 3: 0 percentage points above; the measured number falls inside the stated range.
By their numbers in this assay, from the lowest: compounds 1 and 3 (each within the scatter of the next); then compound 2.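

On the core of compound 1, the exchange of cyclohexyl for benzyl on the aromatic nitrogen gives a number 2.4 percentage points higher from compound 1 to compound 3 (within the scatter) in this assay. Going by these compounds alone, a non-aromatic ring of carbon only and an aromatic ring of carbon only, the latter carried as benzyl, therefore cannot be told apart at this position on this read-out, and this is the first reading of any change at this nitrogen. Nothing available accounts for this result.

From the compounds shown here alone, it remains open whether benzyl would read the same way on compound 2, the 4-fluorophenyl compound, whose number in this assay stands higher. Going by these compounds, it is also open whether an amine, a carboxylic acid or a longer chain on this nitrogen would move the number beyond the scatter.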